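Methoxy in place of hydrogen on the core of compound 1

The source may hold more compounds than are shown below. What is called first, only, known or untested is meant among the compounds shown, and "the series" means these compounds.

Compound 1, `CC(C)(C)OC(=O)/C=C1/C(=O)Nc2ccccc21`: 87.3%
Compound 2, `CC(C)(C)OC(=O)/C=C1/C(=O)N(Cc2ccccc2)c2ccccc21`: 88%
Compound 3, `CCCCc1ccc2c(c1)/C(=C\C(=O)OC(C)(C)C)C(=O)N2`: 87.8%

All three were tested in a functional assay on SK-BR-3 cells (Homo sapiens) for inhibition, read by CCK-8 assay, with a stated time of 72 h, tested at 20 uM; a lower number here means less inhibition of growth, a higher number more inhibition of growth at the concentration tested. Compound 1 stands within the scatter of both companions: the step of a number 0.7 percentage points higher from compound 1 to compound 2 (within the scatter) and the step of a number 0.5 percentage points higher from compound 1 to compound 3 (within the scatter) are each too small to count as a change. Compound 4, `COc1ccc2c(c1)/C(=C\C(=O)OC(C)(C)C)C(=O)N2`, is compound 1 with methoxy in place of hydrogen on an aromatic carbon. The step that bears most directly on it is the one on an aromatic carbon, from compound 1 to compound 3, which stayed within the scatter; the change on the ring nitrogen did the same. Because a number 0.5 percentage points higher from compound 1 to compound 3 (within the scatter) was flat, compound 4 is expected to show no step beyond the scatter, that is a number 0.3 percentage points lower from compound 1 to compound 4 (within the scatter). Compound 4 is therefore estimated at 87%, between 78% and 94%.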

Compound 4, percent growth inhibition at one concentration: 87.7%
Compound 4: middle estimate off by 0.7 percentage points, on the low side; the measured number falls inside the stated range.
By their numbers in this assay, from the lowest: compounds 1, 4, 3 and 2 (each within the scatter of the next).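

In this assay methoxy on this aromatic carbon gives a number 0.4 percentage points higher from compound 1 to compound 4 (within the scatter) and, set in place of butyl on the same carbon, gives a number 0.1 percentage points lower from compound 3 to compound 4 (within the scatter) as well. Hydrogen, butyl and methoxy at this position therefore cannot be told apart at this one concentration, which extends the flat result from a chain to an oxygen-linked group. Nothing available explains this flat result. From the compounds shown here alone, whether an amine or a carboxylic acid on this aromatic carbon would move the number beyond the scatter stays open. So does whether these compounds would separate at lower concentrations.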